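The source may report more compounds than this note shows. Statements on the series, on what has been measured and on what is new or still open speak of the compounds shown alone.

Two compounds of the series have numbers in an assay on HEK293 cells for activation of Kir3.1/Kir3.2 (Homo sapiens), read by thallium flux; a lower number here means that less compound is needed, a higher number that more compound is needed for the effect. Compound 1 `Cc1cc(NC(=O)Cn2nnc(-c3ccccc3)n2)n(C2CCCCC2)n1` gives 96 nM. Compound 2 `COc1ccc(-c2nnn(CC(=O)Nc3cc(C)nn3C3CCCCC3)n2)cc1` gives 175 nM, the larger of the two numbers, yet a 1.8-fold higher number from compound 1 to compound 2 (0.26 log units; within the scatter) keeps it within the scatter of compound 1. Compound 3 `Cc1cc(NC(=O)Cn2nnc(-c3ccc(Cl)c(C)c3)n2)n(C2CCCCC2)n1` differs from compound 2 by 4-chloro-3-methylphenyl in place of 4-methoxyphenyl on an aromatic carbon. For the measured compounds named here, no measured step covers a chloro or methyl on that ring; the only step in hand, on the same ring, stayed within the scatter. Compound 3 is therefore expected to shift by a 1.5-fold lower number from compound 2 to compound 3 (0.16 log units; within the scatter), nothing beyond the scatter. Compound 3 is estimated at 120 nM, range 40 nM to 400 nM.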

Compound 3, half-maximal effective concentration: 712 nM
Estimate against measurement, compound 3: 5.9-fold (0.77 log units) below, outside the stated range (above it).
By their numbers in this assay, from the lowest: compounds 1 and 2 (each within the scatter of the next); then compound 3.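

In this assay, the aryl group on the five-membered aromatic ring with 4 nitrogen is not a freely interchangeable position: 4-chloro-3-methylphenyl gives a 4.1-fold higher number from compound 2 to compound 3 (0.61 log units; beyond the scatter) and a 7.4-fold higher number from compound 1 to compound 3 (0.87 log units; beyond the scatter), whereas the methoxy step stayed within the scatter. Both steps run towards more compound being needed, so this ring tolerates some substituents but not all. The data offer no explanation for this step.

Chloro and methyl enter together, so the contribution of each remains unresolved. Also open, as far as these compounds go, is how an amine or a carboxylic acid on this ring would compare with the phenyl of compound 1.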